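This account rests on a few compounds, and the source may have more. Where it says the series, first, only, none or still open, it means among the compounds named here.

Three compounds sharing one core have been examined in an ADME assay on HepG2 2.2.15 cells (Homo sapiens) for cytotoxicity (on this read-out higher numbers stand for lower toxicity in this test and lower numbers for higher toxicity in this test), a test that asks how much of a substance liver-derived cells in culture can tolerate before they begin to die. Compound 1 `Cc1cc(Br)cc(OC(c2ccc(Cl)cc2)c2cnc(NC(=O)OC(C)(C)C)s2)c1` comes first. In this assay compound 1 reaches only a limit of the test, > 50000 nM, so no number is known for it. Compound 2 `O=C(Nc1ncc(C(OCc2ccc(Br)cc2)c2ccccc2)s1)c1cccs1` follows; in this assay compound 2 is reported as "not toxic" (no number reported), without a number. Compound 3 `COC(=O)CCCCNc1ncc(C(Oc2ccc3cc(Br)ccc3c2)c2ccc(Cl)cc2)s1` carries a 4-(methoxycarbonyl)butyl chain on a nitrogen on an aromatic ring, and in this assay compound 3 is likewise reported as "not toxic" (no number reported), again with no number. Compound 3 therefore stands without a number of its own, beside one value that is a limit of > 50000 nM in this assay, at which 1 of the 3 values shown sits, and one further entry that has none. Compound 4 `O=C(Nc1ncc(C(Oc2ccc3cc(Br)ccc3c2)c2ccc(Cl)cc2)s1)c1ccc(F)cc1F` differs from compound 3 in a single place: (2,4-difluorophenyl)carbonyl in place of 4-(methoxycarbonyl)butyl on a nitrogen on an aromatic ring. Going by the values given here, no step between measured compounds has been sized, so the size of this change in this assay cannot be read from the data. All three measured compounds sit at or beyond what the test can resolve, and no step beyond the usual scatter is expected. Compound 4 is accordingly estimated to show about 50000 nM in this assay, within roughly 20000 nM to 120000 nM, with a fair chance that only a limit is reported once more.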

Compound 4, half-maximal cytotoxic concentration: "not toxic" (no number reported)
The entry for compound 4 holds no number; no gap can be computed for the estimate.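

Compound 3 and compound 4 are both reported as "not toxic" without a number in this assay, so no step can be read between them. The compounds shown leave open how much of each the cells can tolerate, and whether exchanging 4-(methoxycarbonyl)butyl for (2,4-difluorophenyl)carbonyl shifts that tolerance at all.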